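Replacing the Dimethylpiperidine in a Weak Adenosine Antagonist

This account rests on a few compounds, and the source may have more. Where it says the series, first, only, none or still open, it means among the compounds named here.

Compound 1 `CC(C)c1ccc(-c2nc(N)c3cc(CN4[C@H](C)CCC[C@@H]4C)sc3n2)o1` and compound 2 `C[C@@H]1CCC[C@H](C)N1Cc1cc2c(N)nc(-c3ccc(C(F)F)o3)nc2s1` share a core and differ only in one group on an aromatic carbon. In an assay on CHO-K1 cells for antagonist activity at adenosine receptor A1 (Homo sapiens), read by a beta-galactosidase reporter, with stated times of 15 min and 6 h (a higher number here means a weaker inhibitor, a lower number a stronger inhibitor), compound 1 gives 140 nM, and compound 2 gives 730 nM, so compound 2 has the highest number of the two, with the step of a 5.2-fold higher number from compound 1 to compound 2 (0.72 log units; beyond the scatter). Compound 3 `Nc1nc(-c2ccc(C(F)F)o2)nc2sc(CN3CCC(F)(F)CC3)cc12` is not yet measured. It differs from compound 2 in another part of the molecule: 4,4-difluoropiperidin-1-yl in place of 2,6-dimethylpiperidin-1-yl on a saturated chain carbon bound to an aromatic carbon. For the measured compounds named here, no measured step touches this position, since the only known step concerns the group on the aromatic carbon, so nothing here tells how the change at the saturated chain carbon will read in this assay. In the absence of a precedent, compound 3 is expected to land near compound 2, with a wide range, estimated at 1500 nM (from 400 nM to 6000 nM), which means an expected step of a 2.1-fold higher number from compound 2 to compound 3 (0.31 log units; beyond the scatter).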

Compound 3, inhibition constant: 17800 nM
The estimate for compound 3 lay 12-fold (1.07 log units) below the measured number; the measured number lies above the stated range.
By their numbers in this assay, from the lowest: compound 1; then compound 2; then compound 3.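

Compound 3 shows that the group on the saturated chain carbon matters in this assay: 4,4-difluoropiperidin-1-yl in place of 2,6-dimethylpiperidin-1-yl gives a large step (a 24-fold higher number from compound 2 to compound 3 (1.39 log units; beyond the scatter)) toward a weaker inhibitor. The two groups have the same count of heavy atoms and each has one six-membered non-aromatic ring, so a change in either of those counts does not accompany this step; the swap replaces a carbon-substituted ring bearing 2 defined stereocentres with a fluorinated ring that has none. Nothing measured here explains why the number rises.

Two methyl groups leave and two fluorines enter in one step, so the compounds shown cannot tell which of these changes accounts for the rise. An unsubstituted piperidin-1-yl at this place would separate the two, and pairing 4,4-difluoropiperidin-1-yl with the isopropyl group of compound 1 would show whether the step holds there.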